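The source may report more compounds than this note shows. Statements on the series, on what has been measured and on what is new or still open speak of the compounds shown alone.

Working notes on the series. In a functional assay on HL-60 cells (Homo sapiens) for antiproliferative activity, read by MTT assay, with a stated time of 48 h (a higher number here means a weaker inhibitor, a lower number a stronger inhibitor), compound 1 `CC(C)=CCC[C@]1(C)/C=C/[C@@H](OC(=O)C=C(C)C)[C@](C)(O)/C=C/C(=O)/C(C[Si](C)(C)C(C)(C)C)=C\C1` gives 2770 nM and compound 2 `CC(C)=CCC[C@]1(C)/C=C/[C@@H](OC(=O)C=C(C)C)[C@](C)(O)/C=C/C(=O)/C(Cn2cc(CO)nn2)=C\C1` gives 3200 nM. For the measured compounds named here, compound 2 therefore stands level with compound 1, the only other measured member, and the two values lie within the scatter of each other.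

Compound 3 `CCN(CC)C(=O)/C1=C/C[C@](C)(CCC=C(C)C)/C=C/[C@@H](OC(=O)C=C(C)C)[C@](C)(O)/C=C/C1=O` has no reading yet. The change from compound 2 is diethylcarbamoyl in place of (4-(hydroxymethyl)-1H-1,2,3-triazol-1-yl)methyl on a double-bonded ring carbon.

Going by the values given here, one measured step bears on this, a 1.2-fold higher number from compound 1 to compound 2 (0.06 log units; within the scatter). It exchanged a silicon-bearing group for the triazole-containing group at the same ring carbon and stayed within the scatter. That is thin evidence: it is a single step, and no diethylcarbamoyl group has been measured on the shared core. Nothing beyond the scatter is expected in this assay, and no direction can be assigned, though the range must stay wide.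

The expected step is a 1.1-fold lower number from compound 2 to compound 3 (0.03 log units; within the scatter). Compound 3 is estimated at 3000 nM, with an expected range of 1100 nM to 8000 nM.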

Compound 3, half-maximal inhibitory concentration: 9080 nM
Estimate against measurement, compound 3: 3.0-fold (0.48 log units) below; measured number above the stated range.
By their numbers in this assay, from the lowest: compounds 1 and 2 (each within the scatter of the next); then compound 3.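

In this assay this double-bonded ring carbon proves sensitive to its substituent: diethylcarbamoyl in place of (4-(hydroxymethyl)-1H-1,2,3-triazol-1-yl)methyl gives a 2.8-fold higher number from compound 2 to compound 3 (0.45 log units; beyond the scatter) and, set against the silicon-bearing group, gives a 3.3-fold higher number from compound 1 to compound 3 (0.52 log units; beyond the scatter), both modest, whereas the earlier exchange gave only a 1.2-fold higher number from compound 1 to compound 2 (0.06 log units; within the scatter) and stayed within the scatter. The three compounds divide by the atom attached to the ring carbon, a saturated chain carbon in compounds 1 and 2 and a carbonyl carbon in compound 3, but with compound 3 alone on its side this is an observation and not yet a pattern. Nothing at hand explains the higher number of compound 3.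

The compounds shown leave open whether that number goes with the carbonyl on the ring carbon or with the two ethyl groups on the amide nitrogen, a question on which a primary amide, a carboxylic acid or a diethylaminomethyl group at the same carbon would bear. They also leave open whether any group at this carbon can bring the number below that of compounds 1 and 2.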